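Aryl variation at the five-membered ring: indolyl to hydroxyphenyl

The source may report more compounds than this note shows. Statements on the series, on what has been measured and on what is new or still open speak of the compounds shown alone.

Measured so far in a functional assay on MDA-MB-231 cells (Homo sapiens) for inhibition, read by MTT assay, with a stated time of 48 h; a lower number here means a stronger inhibitor, a higher number a weaker inhibitor:
compound 1 `COc1cc(-c2nccn3cc(-c4ccc(Cl)cc4)nc23)cc(OC)c1OC`: 2090 nM
compound 2 `COc1cc(-c2nccn3cc(-c4ccc5[nH]ccc5c4)nc23)cc(OC)c1OC`: 74 nM
compound 3 `COc1cc(-c2nccn3cc(-c4ccccc4)nc23)cc(OC)c1OC`: 364 nM

Compound 2 gives the lowest number of the three; compound 3 lies a 4.9-fold higher number from compound 2 to compound 3 (0.69 log units; beyond the scatter) and compound 1 lies a 28-fold lower number from compound 1 to compound 2 (1.45 log units; beyond the scatter). Compound 4 `COc1cc(-c2nccn3cc(-c4ccc(O)cc4)nc23)cc(OC)c1OC` is not yet measured. Change from compound 2: 4-hydroxyphenyl in place of 1H-indol-5-yl on an aromatic carbon.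

The bearing steps are a 4.9-fold higher number from compound 2 to compound 3 (0.69 log units; beyond the scatter), which replaces the same group by an unsubstituted ring, and a 5.7-fold lower number from compound 1 to compound 3 (0.76 log units; beyond the scatter), which shows a para substituent of another kind costing potency. Among the measured compounds shown here, no step with a hydroxyphenyl is available. A modest rise of the number from compound 2, toward that of compound 3, is therefore expected: a 4.1-fold higher number from compound 2 to compound 4 (0.61 log units; beyond the scatter). Compound 4 is estimated at 300 nM, range 80 nM to 1200 nM.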

Compound 4, half-maximal inhibitory concentration: > 10000 nM
Compound 4 gave a limit, no number; the forecaster's own chance of this, stated with the estimate: 3%; at least 33-fold (1.52 log units) between middle value and limit.
By their numbers in this assay, from the lowest: compound 2; then compound 3; then compound 1. At a limit, above all of these: compound 4.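

Compound 4 gives no number in this assay, only a limit: the limit of > 10000 nM in this assay, at which 1 of the 4 values shown sits.

Hydroxy in place of hydrogen brings an at least 27-fold higher number from compound 3 to compound 4 (1.43 log units; beyond the scatter), and hydroxy in place of chloro brings an at least 4.7-fold higher number from compound 1 to compound 4 (0.67 log units; beyond the scatter), so on this phenyl ring the identity of the substituent matters, not only its presence. 1H-indol-5-yl and 4-hydroxyphenyl each carry a hydrogen-bond donor, yet the exchange gives an at least 130-fold higher number from compound 2 to compound 4 (2.13 log units; beyond the scatter), so the two groups are not interchangeable here.

From the compounds shown here alone, whether a methoxy or an amine on the same phenyl ring would follow chloro or hydroxy remains open.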